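A Substituent Swap on the Triazole-Bearing Side Chain

The source may hold more compounds than are shown below. What is called first, only, known or untested is meant among the compounds shown, and "the series" means these compounds.

Compound 1 `COc1ccc([C@@H]2C/C(=N/OCc3cn(-c4ccc(Cl)cc4C)nn3)c3cc(CC=C(C)C)c(OC)cc3O2)cc1` carries a 4-chloro-2-methylphenyl group on an aromatic nitrogen. In a functional assay on HCT-116 cells (Homo sapiens) for inhibition, read by sulforhodamine B assay, with a stated time of 48 h, tested at 50 uM (on this read-out higher numbers stand for more inhibition of growth at the one concentration tested and lower numbers for less inhibition of growth), compound 1 gives 20%, the lowest of the two numbers available; compound 2 `COc1cc2c(cc1CC=C(C)C)C(=O)C[C@@H](c1ccc(Oc3cccc([N+](=O)[O-])c3)cc1)O2` gives 46%, a difference beyond the usual scatter. Compound 3 `COc1ccc([C@@H]2C/C(=N/OCc3cn(-c4cccc(CO)c4)nn3)c3cc(CC=C(C)C)c(OC)cc3O2)cc1` differs from compound 1 in one place: 3-(hydroxymethyl)phenyl in place of 4-chloro-2-methylphenyl on an aromatic nitrogen. For the measured compounds named here, no measured pair with a matching change exists, so the expectation rests on compound 1 alone, and the step of a number 2 percentage points lower from compound 1 to compound 3 (within the scatter) is expected to stay within the scatter, with no clear direction. Compound 3 is therefore estimated at 18%, within 2% to 38%.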

Compound 3, percent growth inhibition at one concentration: 27%
Compound 3: the middle estimate sits 9 percentage points below what was measured, within the range that was stated.
By their numbers in this assay, from the lowest: compounds 1 and 3 (each within the scatter of the next); then compound 2.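

Putting 3-(hydroxymethyl)phenyl in place of 4-chloro-2-methylphenyl on this aromatic nitrogen gives, in this assay, a number 7 percentage points higher from compound 1 to compound 3 (within the scatter) and so does not separate the two groups. For the compounds shown here, this is the first direct test of this position, since compound 2 differs from compound 1 in more than one place. Here, exchanging the chlorine and methyl groups for a hydroxymethyl group, which brings a hydrogen-bond donor, leaves the two compounds indistinguishable.

From the compounds shown here alone, whether an amine or a carboxylic acid on this phenyl ring would move the number beyond the scatter stays open. Nothing available explains the size of this step.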